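A few compounds are considered here, and "the series" means these few. Any claim that something is new, unique, unknown or untested is made for them only; others in the source may bear on it.

Measured compounds in a functional assay on MCF7 cells (Homo sapiens) for cytotoxicity, read by MTT assay, with a stated time of 48 h; on this read-out higher numbers stand for weaker inhibition and lower numbers for stronger inhibition:

- compound 1, `Cc1noc2c1N=C(c1ccc(Cl)cc1)CC(c1ccccc1)C2C(c1ccccc1)C1c2onc(C)c2N=C(c2ccc(Cl)cc2)CC1c1ccccc1`, gives 61.1 ug/mL
- compound 2, `Cc1noc2c1N=C(c1ccccc1)CC(c1ccccc1)C2C(c1ccccc1)C1c2onc(C)c2N=C(c2ccccc2)CC1c1ccccc1`, gives 68.9 ug/mL
- compound 3, `Cc1noc2c1N=C(c1ccco1)CC(c1ccccc1)C2C(c1ccccc1)C1c2onc(C)c2N=C(c2ccco2)CC1c1ccccc1`, gives 35.9 ug/mL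

Of the compounds shown here, three sharing one core have been tested so far, and they differ only in the aromatic ring carried on each side of the symmetric scaffold. Compound 2 stands at the highest of the three numbers in this assay, but every gap is small: compound 1 sits close by, and even compound 3, the furthest away, lies within the usual scatter of repeated measurements. Among the measured compounds shown here, on these numbers alone, then, no compound can be set apart from the others.

Compound 4, `COc1ccc(C(C2c3onc(C)c3N=C(c3ccccc3)CC2c2ccccc2)C2c3onc(C)c3N=C(c3ccccc3)CC2c2ccccc2)cc1`, has not yet been measured. It departs from compound 2 in a single place: methoxy in place of hydrogen on an aromatic carbon. Cut one bond further out, the same change reads phenyl to 4-methoxyphenyl, on the central ring that links the two halves of the core.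

For the measured compounds named here, no measured pair shows what such a change does here. Nothing among the three measured compounds shows that changing an aromatic ring shifts the numbers beyond the scatter, so the step of a 1.1-fold lower number from compound 2 to compound 4 (0.06 log units; within the scatter) is expected to be none beyond the scatter. Compound 4 is therefore estimated to give 60 ug/mL, within a range from 30 ug/mL to 120 ug/mL.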

Compound 4, half-maximal inhibitory concentration: 57.3 ug/mL
Beside the measured number, compound 4's estimate is 1.0-fold (0.02 log units) above it, and the stated range covers the measured number.
By their numbers in this assay, from the lowest: compounds 3, 4, 1 and 2 (each within the scatter of the next).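

Among the compounds shown here, compound 2 and compound 4 form the first pair here that differs in only one place, so a single change can now be read on its own. In this assay, methoxy in place of hydrogen on an aromatic carbon, para to a large group, gives a 1.2-fold lower number from compound 2 to compound 4 (0.08 log units; within the scatter) and thus no shift that can be told from repeat-measurement noise, so at this position the change from phenyl to 4-methoxyphenyl leaves the read-out effectively where it was. Nothing shown here offers any explanation for this result.

As far as these compounds go, whether an amine or a carboxylic acid at this same position would also leave the number in place remains open. So does whether methoxy would behave the same way on the other aromatic rings of the shared core.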